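Replacing a chlorophenyl urea with a tolyl urea

This account rests on a few compounds, and the source may have more. Where it says the series, first, only, none or still open, it means among the compounds named here.

Of the compounds shown here, three of a shared core have been measured in a functional assay on MDA-MB-231 cells (Homo sapiens) for cytotoxicity, read by MTT assay, with a stated time of 72 h; on this read-out higher numbers stand for weaker inhibition and lower numbers for stronger inhibition. Compound 1 `Cc1ccc(NC(=O)Nc2ccc(-c3nc(NCCCN(C)C)c4sc(Cl)c(Cl)c4n3)cc2)cc1` gives 4980 nM in this assay, and compound 2 `CCN(CC)CCCNc1nc(-c2ccc(NC(=O)Nc3ccc(C)cc3)cc2)nc2c(Cl)c(Cl)sc12` gives 3040 nM; the step of a 1.6-fold lower number from compound 1 to compound 2 (0.21 log units; within the scatter) changes only the amine. Compound 3 `CCN(CC)CCNc1nc(-c2ccc(NC(=O)Nc3ccccc3Cl)cc2)nc2c(Cl)c(Cl)sc12` gives 1410 nM, the lowest of the three numbers, with compound 2 nearest and compound 1 furthest, both beyond the scatter.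

Compound 4 `CCN(CC)CCNc1nc(-c2ccc(NC(=O)Nc3ccc(C)cc3)cc2)nc2c(Cl)c(Cl)sc12` has not yet been measured in this assay. It differs from compound 3 by 4-methylphenyl in place of 2-chlorophenyl on an amide-type nitrogen. Among the measured compounds shown here, no measured step isolates this aryl change: compound 2 carries the same 4-methylphenyl urea but a longer chain, so its value shows only where a tolyl urea with a related amine lands. Compound 2 and compound 3 differ in two places at once, and their gap cannot be split between them.

Compound 4 is therefore expected to give a somewhat higher number than compound 3, a step of about a 1.6-fold higher number from compound 3 to compound 4 (0.21 log units; within the scatter), landing near the value of compound 2. The estimate for compound 4 is 2300 nM, within a range from 900 nM to 5800 nM.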

Compound 4, half-maximal inhibitory concentration: 2010 nM
Compound 4: the middle estimate sits 1.1-fold (0.06 log units) above what was measured; measured number inside the range.
By their numbers in this assay, from the lowest: compounds 3, 4, 2 and 1 (each within the scatter of the next, the first and the last beyond it).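

In this assay, 4-methylphenyl in place of 2-chlorophenyl on the amide-type nitrogen gives a 1.4-fold higher number from compound 3 to compound 4 (0.15 log units; within the scatter), so with the amine held fixed this aryl change does not move the number beyond the usual scatter. Among the compounds shown here, with the 4-methylphenyl urea held fixed, the amine side can also be read on its own: diethylamino in place of (diethylamino)methyl gives a 1.5-fold lower number from compound 2 to compound 4 (0.18 log units; within the scatter), and diethylamino in place of (dimethylamino)methyl gives a 2.5-fold lower number from compound 1 to compound 4 (0.39 log units; beyond the scatter), the only one of these three steps beyond the scatter. Nothing measured here accounts for these steps.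

The compounds shown leave open how a methoxy group or a carboxylic acid on this aryl ring would read. They also leave open what a cyclic amine such as morpholine at the end of the chain would do.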